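A few compounds are considered here, and "the series" means these few. Any claim that something is new, unique, unknown or untested is made for them only; others in the source may bear on it.

Measured compounds:
compound 1 `COc1cc[nH]c1/C=C1\C(=O)Nc2ccc(F)c(C#C[C@@H](C)O)c21`, 130 nM
compound 2 `COc1cc[nH]c1/C=C1\C(=O)Nc2ccc(F)c(C#C[C@H](CO)NCCO)c21`, 967 nM

In a functional assay on SW480 cells (Homo sapiens) for inhibition (a lower number here means a stronger inhibitor, a higher number a weaker inhibitor), compound 1 holds the lowest of the two numbers; its nearest neighbour is compound 2, reached by a 7.4-fold higher number from compound 1 to compound 2 (0.87 log units; beyond the scatter). Compound 3 `COc1cc[nH]c1/C=C1\C(=O)Nc2ccc(F)c(C#C[C@@H](NS(C)(=O)=O)[C@@H](C)O)c21` is not yet measured in this assay. It differs from compound 1 as follows: 2-hydroxy-1-(methanesulfonamido)propyl in place of 1-hydroxyethyl on a triple-bonded carbon. Within the data shown here, the one measured step that bears on this change is the one from compound 1 to compound 2, which likewise replaced 1-hydroxyethyl on a triple-bonded carbon and produced a 7.4-fold higher number from compound 1 to compound 2 (0.87 log units; beyond the scatter). Compound 3 keeps a hydroxyl in the entering group and adds the methanesulfonamido, so a rise of the number in this assay is expected, though somewhat smaller than that step. For compound 3 the estimate in this assay is 500 nM, with a range from 150 nM to 1600 nM. This expectation corresponds to a 3.8-fold higher number from compound 1 to compound 3 (0.59 log units; beyond the scatter).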

Compound 3, half-maximal inhibitory concentration: 1190 nM
For compound 3 the middle estimate is 2.4-fold (0.38 log units) below the measured one; the range from low to high includes it.
By their numbers in this assay, from the lowest: compound 1; then compounds 2 and 3 (each within the scatter of the next).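

In this assay, 2-hydroxy-1-(methanesulfonamido)propyl in place of 1-hydroxyethyl on a triple-bonded carbon gives a 9.2-fold higher number from compound 1 to compound 3 (0.96 log units; beyond the scatter), so a second entering group of a different kind now stands clearly apart from compound 1. The two larger groups are not told apart at this place, with a 1.2-fold higher number from compound 2 to compound 3 (0.09 log units; within the scatter), and the sulfonamide and the amino-alcohol chain therefore give matching results here. Nothing available explains this outcome.

The compounds shown leave open whether a simple amine or a longer chain ending in a hydroxyl on the triple-bonded carbon would stay close to compound 1 or match compound 2 and compound 3. They also leave open which part of the 2-hydroxy-1-(methanesulfonamido)propyl group accounts for its step from compound 1, since the methanesulfonamido and the added carbon enter together.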